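Replacing 2-(methylsulfanyl)phenyl with 4-fluorophenyl

The compounds below may be only part of what the source reports. "The series", "measured", "known", "first", "only" and "open" are said of these compounds alone.

Measured in a functional assay on HCT-116 cells (Homo sapiens) for cytotoxicity, with a stated time of 48 h (on this read-out higher numbers stand for weaker inhibition and lower numbers for stronger inhibition), so far
Compound 1 `COc1cc(OC)c(C(=O)/C=C/c2ccccc2OC)c(OC)c1` gives 4200 nM
Compound 2 `COc1cc(OC)c(C(=O)/C=C/c2ccccc2SC)c(OC)c1` gives 6800 nM
Compound 3 `COc1cccc(/C=C/C(=O)c2c(OC)cc(OC)cc2OC)c1` gives 4300 nM

Compound 2 stands within the scatter of both other compounds, with a 1.6-fold higher number from compound 1 to compound 2 (0.21 log units; within the scatter) and a 1.6-fold lower number from compound 2 to compound 3 (0.20 log units; within the scatter) as its steps. Compound 4 `COc1cc(OC)c(C(=O)/C=C/c2ccc(F)cc2)c(OC)c1` remains unmeasured. It carries 4-fluorophenyl in place of 2-(methylsulfanyl)phenyl on a double-bonded chain carbon bound to a double-bonded chain carbon. The nearest evidence is the exchange of that same group in a 1.6-fold lower number from compound 2 to compound 3 (0.20 log units; within the scatter) and the change among the aryl groups in a 1.0-fold higher number from compound 1 to compound 3 (0.01 log units; within the scatter) and both stayed within the scatter. Among the compounds with values here, no measured compound carries fluorine, so this expectation is tentative. The expected step is a 1.4-fold lower number from compound 2 to compound 4 (0.13 log units; within the scatter) and no step beyond the scatter is expected in this assay here. For compound 4 the estimated value is 5000 nM with an expected range from 2200 nM to 11000 nM as its limits.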

Compound 4, half-maximal inhibitory concentration: 6200 nM
The estimate for compound 4 lay 1.2-fold (0.09 log units) below the measured number; the measured number falls inside the stated range.
By their numbers in this assay, from the lowest: compounds 1, 3, 4 and 2 (each within the scatter of the next).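

In this assay, 4-fluorophenyl on a double-bonded chain carbon bound to a double-bonded chain carbon stays within the scatter of all three earlier aryl groups (a 1.1-fold lower number from compound 2 to compound 4 (0.04 log units; within the scatter); a 1.4-fold higher number from compound 3 to compound 4 (0.16 log units; within the scatter); a 1.5-fold higher number from compound 1 to compound 4 (0.17 log units; within the scatter)). Fluorine on this ring thus joins methoxy and methylsulfanyl among the substituents that produce no step beyond the scatter here. Nothing at hand explains why this position responds so little.

As far as these compounds go, whether an amine or a carboxylic acid on this ring would move the number beyond the scatter remains open. So does whether this flat response would hold with any other group in place of the trimethoxy-substituted part of the shared core.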